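Piperidinyl for pyridinylethyl: solubility outlook for compound 3

This account rests on a few compounds, and the source may have more. Where it says the series, first, only, none or still open, it means among the compounds named here.

Compound 1 `Cc1cc(NCCCc2ccccn2)n2nc(C)c(-c3ccccc3)c2n1` was tested in a physicochemical assay for solubility, read by HPLC, using the shake flask method, measured as kinetic solubility, with a stated time of 2 h, at pH 7.4 (a higher number here means a more soluble compound, a lower number a less soluble compound), and gave 5900 nM. Compound 2 `Cc1cc(NCc2ccccn2)n2nc(C)c(Nc3ccccc3)c2n1` belongs to the same series and in this assay compound 2 gave 7800 nM. Of these two numbers, compound 1 holds the lower one, but its nearest neighbour is compound 2 and the gap between them lies within the scatter, so nothing separates the two in this assay.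

Compound 3 `Cc1cc(NCC2CCCCN2)n2nc(C)c(-c3ccccc3)c2n1` has not yet been measured. Relative to compound 1 it differs at one place: piperidin-2-yl in place of 2-(pyridin-2-yl)ethyl on a saturated chain carbon bound to a nitrogen on an aromatic ring. The change sits on a saturated chain carbon bound to a nitrogen on an aromatic ring, the shared core being otherwise unchanged. Among the measured compounds shown here, no step between measured compounds of this set concerns the same change, so the expectation rests on compound 1 alone.

The step from compound 1 to compound 3 is expected to be upward in this assay, at about a 3.1-fold higher number from compound 1 to compound 3 (0.48 log units; beyond the scatter), modest but beyond the scatter. For compound 3 the estimated solubility in this assay is 18000 nM, with a range from 6000 nM to 55000 nM.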

Compound 3, solubility: 189000 nM
For compound 3 the middle estimate is 11-fold (1.02 log units) below the measured one; the whole stated range lies below it.
By their numbers in this assay, from the lowest: compounds 1 and 2 (each within the scatter of the next); then compound 3.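

Among the compounds shown here, at the saturated chain carbon bound to a nitrogen on an aromatic ring, the earlier compounds offered no step, so they gave no sign of how far this place could move the read-out. Placing piperidin-2-yl there in place of 2-(pyridin-2-yl)ethyl now gives, in this assay, a 32-fold higher number from compound 1 to compound 3 (1.51 log units; beyond the scatter), which shows that this position is far from silent in this assay. The single step carries several differences at once, as a six-membered aromatic ring gives way to a six-membered non-aromatic ring, the hydrogen-bond donor count changes and the group becomes smaller, and no measurement shown bears on which of these matters or why the number rises.

From the compounds shown here alone, it remains open whether cyclohexyl, which has no ring nitrogen, or an open-chain amine at this place would give a step of similar size, and whether a shorter chain ending in pyridin-2-yl would already account for part of it. Also open, going by these compounds, is whether piperidin-2-yl would produce a comparable step on the core of compound 2, which carries an anilino group where compound 1 carries phenyl.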